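Fluoro to methoxy on the amine-bound aromatic ring

The source may hold more compounds than are shown below. What is called first, only, known or untested is meant among the compounds shown, and "the series" means these compounds.

Measured so far:
Compound 1, `Cn1ccc2cc(-c3ccc4oc(NC5CCCCC5)nc4c3)ccc21`: 911 nM
Compound 2, `Cn1ccc2cc(-c3ccc4oc(Nc5ccc(F)cc5)nc4c3)ccc21`: 99 nM

Both compounds were tested in an assay on HEK293 cells for inhibition of Fatty-acid amide hydrolase 1 (Homo sapiens), read by fluorescence; on this read-out higher numbers stand for weaker inhibition and lower numbers for stronger inhibition. Among the measured compounds shown here, compound 2 has the lowest number of the two, and its only neighbour is compound 1, whose value sits a clear distance away: a 9.2-fold lower number from compound 1 to compound 2 (0.96 log units; beyond the scatter). That step swapped a saturated ring for an aromatic one on the same nitrogen and was beyond the scatter.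

Compound 3, `COc1ccc(Nc2nc3cc(-c4ccc5c(ccn5C)c4)ccc3o2)cc1`, has not been measured. It differs from compound 2 in one place: methoxy in place of fluoro on an aromatic carbon. The aromatic ring on the nitrogen is kept; only the group at the far side of that ring changes.

For the measured compounds named here, no measured step bears directly on this change. Going by the values given here, the one step known concerns the ring itself, not a substituent on it, so it gives no direction for fluoro versus methoxy. Without such guidance, the expected change is none beyond the scatter. Accordingly the expected step is a 1.2-fold higher number from compound 2 to compound 3 (0.08 log units; within the scatter), which is within the scatter. Compound 3 is estimated at 120 nM, with a range from 40 nM to 400 nM.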

Compound 3, half-maximal inhibitory concentration: 280 nM
Beside the measured number, compound 3's estimate is 2.3-fold (0.37 log units) below it, and the stated range covers the measured number.
By their numbers in this assay, from the lowest: compound 2; then compound 3; then compound 1.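

In this assay, the group at the far side of the aromatic ring on the nitrogen proves to matter: methoxy in place of fluoro gives a 2.8-fold higher number from compound 2 to compound 3 (0.45 log units; beyond the scatter), so this position does not accept both groups equally. The aromatic ring keeps its edge over the saturated one with methoxy on it, as 4-methoxyphenyl in place of cyclohexyl gives a 3.3-fold lower number from compound 1 to compound 3 (0.51 log units; beyond the scatter), but that step is smaller than the one with 4-fluorophenyl, a 9.2-fold lower number from compound 1 to compound 2 (0.96 log units; beyond the scatter), so the gain from the aromatic ring depends on what it carries. No measurement of any property of these groups accompanies the result, so the difference between fluoro and methoxy stays unexplained.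

Going by these compounds, two groups at one position do not make a trend, so it remains open whether a chloro, a hydroxyl or an amine there would land nearer compound 2 or compound 3. Also open, on these data alone, is whether the same exchange of fluoro for methoxy would give a step of similar size elsewhere on that ring.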